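The compounds below may be only part of what the source reports. "The series", "measured", "known", "first", "only" and "open" are said of these compounds alone.

Working notes on the series, all in a functional assay on HeLa cells (Homo sapiens) for inhibition, read by CCK-8 assay, with a stated time of 48 h; a lower number here means a stronger inhibitor, a higher number a weaker inhibitor. Compound 1 (`COc1cc(-c2ccnc3cc(-c4ccccc4)nn23)cc(OC)c1OC`) gives 458 nM, compound 2 (`COc1cc(-c2ccnc3cc(-c4cn(C)c5ccccc45)nn23)cc(OC)c1OC`) gives 399 nM and compound 3 (`COc1cc(-c2ccnc3cc(-c4ccc(N(C)C)cc4)nn23)cc(OC)c1OC`) gives 378 nM. Compound 3 stands level with the other two: a 1.2-fold lower number from compound 1 to compound 3 (0.08 log units; within the scatter) and a 1.1-fold lower number from compound 2 to compound 3 (0.02 log units; within the scatter). The remaining comparison is a 1.1-fold lower number from compound 1 to compound 2 (0.06 log units; within the scatter).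

Compound 4 (`COc1cc(-c2ccnc3cc(-c4ccc5cnn(C)c5c4)nn23)cc(OC)c1OC`) has 1-methyl-1H-indazol-6-yl in place of 4-(dimethylamino)phenyl on an aromatic carbon. All three measured steps change the group at this place, and none leaves the scatter. On that evidence, no step beyond the scatter is expected in this assay, and the estimated change is a 1.1-fold lower number from compound 3 to compound 4 (0.03 log units; within the scatter). Compound 4 is expected at 350 nM, with an estimated range of 100 nM to 1100 nM.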

Compound 4, half-maximal inhibitory concentration: 97 nM
Estimate against measurement, compound 4: 3.6-fold (0.56 log units) above; measured number outside the range, below it.
By their numbers in this assay, from the lowest: compound 4; then compounds 3, 2 and 1 (each within the scatter of the next).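

In this assay this position proves sensitive to the group it carries: 1-methyl-1H-indazol-6-yl stands apart from 4-(dimethylamino)phenyl (a 3.9-fold lower number from compound 3 to compound 4 (0.59 log units; beyond the scatter)), from 1-methyl-1H-indol-3-yl (a 4.1-fold lower number from compound 2 to compound 4 (0.61 log units; beyond the scatter)) and from phenyl (a 4.7-fold lower number from compound 1 to compound 4 (0.67 log units; beyond the scatter)). For the compounds shown here, these are the first steps beyond the scatter, and the three earlier groups remain level with one another. Nothing available accounts for the separation of compound 4.

As far as these compounds go, whether the gain follows the second ring nitrogen or the point of attachment stays open. A 1-methyl-1H-indol-6-yl group at this position would separate the two.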